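The source may hold more compounds than are shown below. What is called first, only, known or untested is meant among the compounds shown, and "the series" means these compounds.

Of the compounds shown here, three have so far been measured in an ADME assay on Caco-2 cells (Homo sapiens) for permeability, in the apical to basolateral direction; on this read-out higher numbers stand for higher permeability and lower numbers for lower permeability. Compound 1 `Cn1cncc1CN1CC(N(CC2CCN(C(=O)C(C)(C)C)CC2)S(=O)(=O)c2ccccn2)Cc2cc(C#N)ccc21` gives 0.5 10^-6 cm/s, compound 2 `CCS(=O)(=O)N1CCC(CN(C2Cc3cc(C#N)ccc3N(Cc3cncn3C)C2)S(=O)(=O)c2ccccn2)CC1` gives 0.1 10^-6 cm/s, and compound 3 `Cn1cncc1CN1CC(N(CC2CCN(C(=O)NC(C)(C)C)CC2)S(=O)(=O)c2ccccn2)Cc2cc(C#N)ccc21` gives 0.6 10^-6 cm/s. Compound 3 holds the highest of the three numbers, although its gap to compound 1 is within the scatter; compound 2 sits furthest from it. The measured steps are a 5.0-fold lower number from compound 1 to compound 2 (0.70 log units; beyond the scatter), a 1.2-fold higher number from compound 1 to compound 3 (0.08 log units; within the scatter) and a 6.0-fold higher number from compound 2 to compound 3 (0.78 log units; beyond the scatter): replacing the whole group on the amine nitrogen in the ring moved the number clearly, while changing only what sits on the carbonyl carbon did not.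

Compound 4 `CC(C)OC(=O)N1CCC(CN(C2Cc3cc(C#N)ccc3N(Cc3cncn3C)C2)S(=O)(=O)c2ccccn2)CC1` differs from compound 3 in one place: isopropoxy in place of (tert-butyl)amino on a carbonyl carbon. Among the measured compounds shown here, the step that bears most directly on this change is the one from compound 1 to compound 3, which also altered only the group on a carbonyl carbon and stayed within the scatter. The two larger steps involved ethylsulfonyl, which is not part of this change. A step of roughly a 1.3-fold higher number from compound 3 to compound 4 (0.12 log units; within the scatter) is therefore expected in this assay, that is, nothing beyond the scatter. Compound 4 is estimated at 0.8 10^-6 cm/s, with a range from 0.4 10^-6 cm/s to 1.6 10^-6 cm/s.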

Compound 4, apparent permeability: 1 10^-6 cm/s
Estimate against measurement, compound 4: 1.3-fold (0.10 log units) below, and the stated range covers the measured number.
By their numbers in this assay, from the lowest: compound 2; then compounds 1, 3 and 4 (each within the scatter of the next).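

In this assay, isopropoxy in place of (tert-butyl)amino on a carbonyl carbon gives a 1.7-fold higher number from compound 3 to compound 4 (0.22 log units; within the scatter), so at this position exchanging a group that carries a hydrogen-bond donor for one that carries none leaves the number within the scatter. Isopropoxy in place of tert-butyl on that carbon gives a 2.0-fold higher number from compound 1 to compound 4 (0.30 log units; within the scatter), which means that all three groups seen on this carbonyl carbon read alike, whereas isopropoxycarbonyl in place of ethylsulfonyl on the amine nitrogen in the ring gives a 10-fold higher number from compound 2 to compound 4 (1.00 log units; beyond the scatter), so compound 2 now stands beyond the scatter from each of the other three compounds. Nothing measured here explains why the sulfonyl compound stands apart or why the carbonyl compounds read alike.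

From the compounds shown here alone, it remains open whether a carboxylic acid or a longer chain on the carbonyl carbon would stay with compound 1, compound 3 and compound 4, and where a plain alkyl chain placed directly on the ring nitrogen would fall. Going by these compounds, all four compounds share one core, so it is also open whether these readings would carry over to a different core.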